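This account rests on a few compounds, and the source may have more. Where it says the series, first, only, none or still open, it means among the compounds named here.

The measured compounds:

Compound 1, `N#CC1=C(N)Oc2c(c(-c3ccccc3)nn2-c2ccccc2)C1c1ccc(F)cc1`: 4100 nM
Compound 2, `COc1ccc(-c2nn(C)c3c2C(c2ccc(F)cc2)C(C#N)=C(N)O3)cc1OC`: > 10000 nM
Compound 3, `COc1ccc(-c2nn(-c3ccccc3)c3c2C(c2ccc(F)cc2)C(C#N)=C(N)O3)cc1`: 6000 nM

In a functional assay on NCI-H2122 cells (Homo sapiens) for inhibition, read by microscopy, with a stated time of 10 days (on this read-out lower numbers stand for stronger inhibition and higher numbers for weaker inhibition), compound 1 gives 4100 nM. For compound 2 the value > 10000 nM is a limit of the assay, not a number. Compound 3 gives 6000 nM in this assay, the higher of the two numbers; the step of a 1.5-fold higher number from compound 1 to compound 3 (0.17 log units; within the scatter) is within the scatter, so no order between compound 1 and compound 3 can be stated.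

Compound 4, `COc1ccc(-c2nn(-c3ccccc3)c3c2C(c2ccc(F)cc2)C(C#N)=C(N)O3)cc1OC`, differs from compound 3 by methoxy in place of hydrogen on an aromatic carbon. Among the compounds with values here, only one measured step bears on this, a 1.5-fold higher number from compound 1 to compound 3 (0.17 log units; within the scatter), where a methoxy was also added to an aromatic carbon, and it stayed within the scatter. Compound 2 carries the same two methoxy groups as compound 4 but differs from compound 3 in two places, so only its value in this assay can be noted: it sits at the limit (the limit of > 10000 nM in this assay, at which 1 of the 3 values shown sits).

The step of a 1.2-fold higher number from compound 3 to compound 4 (0.07 log units; within the scatter) is therefore expected to be small, with no change beyond the scatter and some chance that only a limit is returned. Compound 4 is estimated to give 7000 nM in this assay, between 3000 nM and 16000 nM.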

Compound 4, half-maximal inhibitory concentration: 7600 nM
For compound 4 the middle estimate is 1.1-fold (0.04 log units) below the measured one; low and high end bracket the measured number.
By their numbers in this assay, from the lowest: compounds 1, 3 and 4 (each within the scatter of the next). At a limit, above all of these: compound 2.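

Compound 4 gives the first measured result for a second methoxy on this aromatic ring, ortho to a methoxy group, and in this assay going from 4-methoxyphenyl to 3,4-dimethoxyphenyl gives a 1.3-fold higher number from compound 3 to compound 4 (0.10 log units; within the scatter). The full change from phenyl to 3,4-dimethoxyphenyl gives a 1.9-fold higher number from compound 1 to compound 4 (0.27 log units; within the scatter), so neither the single addition nor the two methoxy groups together separate these compounds beyond the scatter. With phenyl in place of methyl on the aromatic nitrogen, the comparison gives an at least 1.3-fold lower number from compound 2 to compound 4 (0.11 log units; that floor lies within the scatter), so no order can be stated for this pair, and the value for compound 2 remains a limit of the assay rather than a number: the limit of > 10000 nM in this assay, at which 1 of the 4 values shown sits.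

The compounds shown leave open whether a different group at this place on the aromatic ring, such as an amine or a carboxylic acid, would move the number beyond the scatter. They also leave open how a longer chain on the aromatic nitrogen would read against phenyl and methyl in this assay.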